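This account rests on a few compounds, and the source may have more. Where it says the series, first, only, none or still open, it means among the compounds named here.

Measured so far in an ADME assay on BJ cells (Homo sapiens) for cytotoxicity, read by MTT assay, with a stated time of 72 h; on this read-out lower numbers stand for higher toxicity in this test and higher numbers for lower toxicity in this test:

- Compound 1 `OC[C@H]1O[C@@H](n2cc(F)c3c(-c4ccco4)ncnc32)[C@H](O)[C@@H]1O`: 310 nM
- Compound 2 `OC[C@H]1O[C@@H](n2cc(Cl)c3c(-c4ccc(F)cc4)ncnc32)[C@H](O)[C@@H]1O`: 49500 nM
- Compound 3 `OC[C@H]1O[C@@H](n2cc(Cl)c3c(-c4ccco4)ncnc32)[C@H](O)[C@@H]1O`: 37300 nM

Compound 3 lies in the upper part of this small range. It is within the scatter of compound 2, as shown by a 1.3-fold lower number from compound 2 to compound 3 (0.12 log units; within the scatter), and well apart from compound 1, as shown by a 120-fold higher number from compound 1 to compound 3 (2.08 log units; beyond the scatter).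

Compound 4 `OC[C@H]1O[C@@H](n2cc(Cl)c3c(-c4ccsc4)ncnc32)[C@H](O)[C@@H]1O` has thiophen-3-yl in place of furan-2-yl on an aromatic carbon. The most relevant measured change at this place is a 1.3-fold lower number from compound 2 to compound 3 (0.12 log units; within the scatter), which stayed within the scatter. The large step of a 120-fold higher number from compound 1 to compound 3 (2.08 log units; beyond the scatter) belongs to the swap of fluoro for chloro, a change not made here, since compound 4 keeps the chloro of compound 3. Within the data shown here, no thiophen-3-yl compound has been measured, so the expectation rests on a single step at this place. No step beyond the scatter is expected in this assay, though a somewhat lower number remains possible. The estimated change is a 1.2-fold lower number from compound 3 to compound 4 (0.09 log units; within the scatter). For compound 4 the expected value is 30000 nM, with an estimated range of 6000 nM to 60000 nM.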

Compound 4, half-maximal cytotoxic concentration: 1720 nM
Beside the measured number, compound 4's estimate is 17-fold (1.24 log units) above it; measured number outside the range, below it.
By their numbers in this assay, from the lowest: compound 1; then compound 4; then compounds 3 and 2 (each within the scatter of the next).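

In this assay, the earlier pair of compound 2 and compound 3 had suggested that this aromatic carbon tolerated a change of ring, yet thiophen-3-yl gives a 22-fold lower number from compound 3 to compound 4 (1.34 log units; beyond the scatter) and a 29-fold lower number from compound 2 to compound 4 (1.46 log units; beyond the scatter), both beyond the scatter. The group at this place therefore can matter, even though furan-2-yl and thiophen-3-yl share the same heavy atom count, ring size and counts of donors and acceptors, and differ in their hetero atom, oxygen or sulfur, and in how the ring is attached. Nothing measured here accounts for the shift.

The compounds shown do not separate the hetero atom from the attachment point, a question that furan-3-yl and thiophen-2-yl would address. They also leave open how a non-aromatic group at this carbon, such as an amine, would behave.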